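Ester to acid on a phenyl-tetrazole FAAH inhibitor

This account rests on a few compounds, and the source may have more. Where it says the series, first, only, none or still open, it means among the compounds named here.

Compound 2 `CCCCCCCCc1ccc(OCC(=O)Cn2nnc(C(=O)OC)n2)cc1` and compound 1 `CCCCCCCCc1ccc(OCC(=O)Cn2nnc(C(=O)O)n2)cc1` share one core; in an assay on microsomes from brain for inhibition of Fatty-acid amide hydrolase 1 (Rattus norvegicus), read by fluorescence and HPLC, with a stated time of 60 min (a lower number here means a stronger inhibitor, a higher number a weaker inhibitor), compound 2 gives 88 nM and compound 1 gives 41 nM. The change hydrogen in place of methyl on an oxygen next to a carbonyl group made a step of a 2.1-fold lower number from compound 2 to compound 1 (0.33 log units; beyond the scatter). Compound 3 `CCCCCCCCc1ccc(OC(C)C(=O)Cn2nnc(-c3ccc(C(=O)OC)cc3)n2)cc1` has a different core; the difference between the two cores is not broken down here. In this assay compound 3 gives 25 nM, the lowest of the three numbers. Compound 4 `CCCCCCCCc1ccc(OC(C)C(=O)Cn2nnc(-c3ccc(C(=O)O)cc3)n2)cc1` is not yet measured and differs from compound 3 by hydrogen in place of methyl on an oxygen next to a carbonyl group, the same change as before. Because the earlier step was a 2.1-fold lower number from compound 2 to compound 1 (0.33 log units; beyond the scatter), a similar but slightly smaller step, a 1.7-fold lower number from compound 3 to compound 4 (0.22 log units; within the scatter), is expected here. Compound 4 is therefore estimated at 15 nM in this assay, with a range from 5 nM to 45 nM.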

Compound 4, half-maximal inhibitory concentration: 50 nM
For compound 4 the middle estimate is 3.3-fold (0.52 log units) below the measured one; the whole stated range lies below it.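

In this assay, putting hydrogen in place of methyl on an oxygen next to a carbonyl group gave a 2.0-fold higher number from compound 3 to compound 4 (0.30 log units; within the scatter). Set beside the earlier step, the same change did not carry over from one core to the other: the same change on two cores in this assay, a 2.1-fold lower number (0.33 log units; beyond the scatter) from compound 2 to compound 1 and a 2.0-fold higher number (0.30 log units; within the scatter) from compound 3 to compound 4, 4.3-fold (0.63 log units) apart, beyond the scatter of two such steps

So the step measured on one core is a poor guide to the step on the other, but two pairs show neither why the steps differ nor any rule for the whole series. Still open, from the compounds shown here alone, is how an ethyl ester or a primary amide in place of methoxycarbonyl would behave on each core. Also open, going by these compounds, is which step, if either, a third core would follow.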